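The compounds below may be only part of what the source reports. "The series", "measured", "known", "first", "only" and "open" are said of these compounds alone.

Measured compounds in a functional assay on the whole organism for inhibition, with Rattus norvegicus as the target, read by paw edema, with stated times of 30 min and 2 h, at a dose of 10 mg/kg by the oral route; a higher number here means more inhibition at the dose given (going by the name of the read-out), a lower number less inhibition:
- compound 1, `O=C1N=C(C2C(=O)c3ccccc3C2=O)CC(c2ccccc2)N1`: 33%
- compound 2, `O=C1N=C(C2C(=O)c3ccccc3C2=O)CC(c2cccc([N+](=O)[O-])c2)N1`: 36%
- compound 3, `O=C1N=C(C2C(=O)c3ccccc3C2=O)CC(c2ccc(Cl)cc2)N1`: 19%

Among these three, compound 3 stands lowest: the step down to it from the first of the other two is a number 14 percentage points lower from compound 1 to compound 3 (beyond the scatter), and the step down to it from the second is a number 17 percentage points lower from compound 2 to compound 3 (beyond the scatter), both beyond the scatter. Compound 4, `CN(C)c1ccc(C2CC(C3C(=O)c4ccccc4C3=O)=NC(=O)N2)cc1`, differs from compound 3 in one place: dimethylamino in place of chloro on an aromatic carbon.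

For the measured compounds named here, no measured step involves dimethylamino, so the bearing steps are indirect. The change from hydrogen to chloro on this ring gave a number 14 percentage points lower from compound 1 to compound 3 (beyond the scatter), and hydrogen to nitro gave a number 3 percentage points higher from compound 1 to compound 2 (within the scatter), so on the numbers shown chloro is the one group that lowered the read-out. Removing chloro and putting in a fresh group is therefore expected to move compound 4 back toward the values of compound 1 and compound 2, giving an estimated step of a number 11 percentage points higher from compound 3 to compound 4 (beyond the scatter). Because chloro alone gave a number 14 percentage points lower from compound 1 to compound 3 (beyond the scatter), compound 4 is expected near 30%, within 15% to 45%.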

Compound 4, a percentage reported as inhibition, in the whole organism at one dose (the size of the read-out at that dose, not a potency): 29%
Compound 4: middle estimate off by 1 percentage points, on the high side; measured number inside the range.
By their numbers in this assay, from the lowest: compounds 3, 4, 1 and 2 (each within the scatter of the next, the first and the last beyond it).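

In this assay, dimethylamino in place of chloro on this aromatic carbon, para to a large group, leaves the two compounds within the scatter of each other (a number 10 percentage points higher from compound 3 to compound 4 (within the scatter)), so this change gives no clear difference. For the compounds shown here, compound 4 also stays within the scatter of the compound with hydrogen on the ring (a number 4 percentage points lower from compound 1 to compound 4 (within the scatter)) and of the 3-nitrophenyl compound (a number 7 percentage points lower from compound 2 to compound 4 (within the scatter)), which makes it the first compound here with no step beyond the scatter to any other, and it shows that a group of three heavy atoms can stand at this place without a clear difference from hydrogen. Nothing measured beyond these percentages helps to explain them.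

The compounds shown leave open how a carboxylic acid or an unsubstituted amine on this same ring carbon would compare with chloro and dimethylamino. They also leave open whether a longer chain on the nitrogen, such as diethylamino in place of dimethylamino, would stay within the scatter of compound 4.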